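The source may hold more compounds than are shown below. What is called first, only, known or untested is meant among the compounds shown, and "the series" means these compounds.

Measured compounds:
Compound 1 `Cc1cc(C)cc(S(=O)(=O)c2c(C(=O)N[C@H]3CCN(Cc4n[nH]c(=O)n4C)C3)[nH]c3ccc(Cl)cc23)c1` — 21500 nM
Compound 2 `Cc1cc(C)cc(S(=O)(=O)c2c(C(=O)N[C@H]3CCN(CC(N)=O)C3)[nH]c3ccc(Cl)cc23)c1` — 28100 nM
Compound 3 `Cc1cc(C)cc(S(=O)(=O)c2c(C(=O)NC3CN(Cc4ccccc4F)C3)[nH]c3ccc(Cl)cc23)c1` — a limit of the assay, > 238000 nM

The three compounds share one core and were read in an ADME assay on MT4 cells (Homo sapiens) for cytotoxicity, read by MTT assay, with a stated time of 5 days; on this read-out lower numbers stand for higher toxicity in this test and higher numbers for lower toxicity in this test. Compound 2 gives the highest of the two actual numbers, and its nearest neighbour is compound 1, with a 1.3-fold higher number from compound 1 to compound 2 (0.12 log units; within the scatter). For compound 3 the assay reports only a limit, > 238000 nM. For the measured compounds named here, the change from the pyrrolidine bearing a carbamoylmethyl group to the azetidine bearing a fluorobenzyl group gave an at least 8.4-fold higher number from compound 2 to compound 3 (0.92 log units; beyond the scatter), and that is the only step that reaches beyond the scatter, since the value of compound 3 sits at the limit of > 238000 nM in this assay, at which 1 of the 3 values shown sits.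

Compound 4 `Cc1cc(C)cc(S(=O)(=O)c2c(C(=O)NS(=O)(=O)c3ccccc3)[nH]c3ccc(Cl)cc23)c1` differs from compound 2 by phenylsulfonyl in place of 1-(carbamoylmethyl)pyrrolidin-3-yl on an amide-type nitrogen. Going by the values given here, this change, like the one leading to compound 3, removes the whole pyrrolidine substituent from the amide-type nitrogen, whereas the small change within that substituent in a 1.3-fold higher number from compound 1 to compound 2 (0.12 log units; within the scatter) stayed within the scatter. A rise toward lower toxicity therefore appears the likelier direction, though an uncertain one. Compound 4 is expected to give about 60000 nM in this assay, within 20000 nM to 240000 nM. The step this expectation implies is a 2.1-fold higher number from compound 2 to compound 4 (0.33 log units; beyond the scatter).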

Compound 4, half-maximal cytotoxic concentration: 167000 nM
Compound 4: middle estimate off by 2.8-fold (0.44 log units), on the low side, and the stated range covers the measured number.
By their numbers in this assay, from the lowest: compounds 1 and 2 (each within the scatter of the next); then compound 4. At a limit, above all of these: compound 3.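

In this assay, phenylsulfonyl in place of 1-(carbamoylmethyl)pyrrolidin-3-yl on the amide-type nitrogen gives a 5.9-fold higher number from compound 2 to compound 4 (0.77 log units; beyond the scatter), so a rise beyond the scatter at this position no longer rests on a limit alone but on an actual number. The entering and leaving groups have the same count of heavy atoms, so this step goes with a change in the kind of group, not in its heavy-atom count. The step of an at least 1.4-fold lower number from compound 3 to compound 4 (0.15 log units; that floor lies within the scatter) does not put the two compounds in order, as compound 3 stands at a limit of the assay: the limit of > 238000 nM in this assay, at which 1 of the 4 values shown sits.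

The compounds shown leave open whether the sulfonyl or the phenyl ring goes with the higher number. A methylsulfonyl or a benzoyl group on the same nitrogen would separate the two.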